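The source may hold more compounds than are shown below. What is called first, only, known or untested is meant among the compounds shown, and "the series" means these compounds.

In an in vitro assay on SH-EP1 cells for displacement of a labelled ligand from Neuronal acetylcholine receptor; alpha4/beta2 (Homo sapiens) (a lower number here means a stronger inhibitor, a higher number a weaker inhibitor), compound 2 `Clc1ccc(C2=CC3CNCC(C2)C3)cn1` gives 0.4 nM; compound 3 `COc1cc(C2=CC3CNCC(C2)C3)cnc1Cl` gives 0.4 nM, and compound 1 `CN1CC2C=C(c3cncc(C#N)c3)CC(C2)C1` gives 24 nM. Compound 2 thus stands level with compound 3, the two together at the low end of the three numbers, while compound 1 sits well above them. Among the compounds with values here, the only measured step starting from compound 2, no change at the digits printed from compound 2 to compound 3 (within the scatter), shows that adding a methoxy is tolerated, but no measured pair exchanges the chloro itself. Compound 4 `C1=C(c2ccc(-c3ccccc3)nc2)CC2CNCC1C2` carries phenyl in place of chloro on an aromatic carbon. With nothing measured to anchor a change of this size, a moderate loss is expected, and the step from compound 2 to compound 4 is estimated at a 10-fold higher number from compound 2 to compound 4 (1.00 log units; beyond the scatter). Compound 4 is therefore expected to give 4 nM in this assay, within 0.8 nM to 30 nM.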

Compound 4, inhibition constant: 105 nM
The estimate for compound 4 lay 26-fold (1.42 log units) below the measured number; measured number above the stated range.
By their numbers in this assay, from the lowest: compounds 2 and 3 (each within the scatter of the next); then compound 1; then compound 4.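

In this assay, within the data shown here, this position proves far less forgiving than the earlier compounds suggested: phenyl in place of chloro gives (a 260-fold higher number from compound 2 to compound 4 (2.42 log units; beyond the scatter)), a large loss, whereas the only earlier step, methoxy in place of hydrogen elsewhere on the ring, gave (no change at the digits printed from compound 2 to compound 3 (within the scatter)). The aromatic carbon next to the ring nitrogen therefore does not take phenyl without a heavy cost, although compound 4 still gives (105 nM). No measurement here bears on the reason for this loss. As far as these compounds go, how a methyl or an amine would fare at this carbon stays open, as does whether a pyridine ring in place of phenyl would recover any of the loss.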